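Chloro to bromo on a hydrazide-linked acid series

The source may report more compounds than this note shows. Statements on the series, on what has been measured and on what is new or still open speak of the compounds shown alone.

Measured so far:
compound 1 `CC(=N)Nc1cccc(C(=O)NNC(=O)CC(CC(=O)O)c2ccc(Cl)cc2)c1` — 2
compound 2 `CC(=N)Nc1cccc(C(=O)NNC(=O)CC(CC(=O)O)c2ccc(Br)cc2)c1` — 2.27
compound 3 `N=C(N)Nc1cccc(C(=O)NNC(=O)NC(CC(=O)O)c2ccc(Cl)cc2)c1` — 1.26

In a physicochemical assay for lipophilicity (a higher number here means a more lipophilic compound, a lower number a more polar compound), compound 1 gives 2 and compound 2 gives 2.27. The two differ by bromo in place of chloro on an aromatic carbon, and this change made a number 0.27 log units higher from compound 1 to compound 2 (within the scatter). Compound 3 has a different core, and the difference between the two cores is not broken down here; in this assay compound 3 gives 1.26, the lowest of the three numbers, beyond the scatter from both compound 1 and compound 2.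

Compound 4 `N=C(N)Nc1cccc(C(=O)NNC(=O)NC(CC(=O)O)c2ccc(Br)cc2)c1` has not yet been measured. It differs from compound 3 by bromo in place of chloro on an aromatic carbon, the same change as that between compound 1 and compound 2, at the same place. Because compound 1 to compound 2 gave a number 0.27 log units higher from compound 1 to compound 2 (within the scatter), a step of similar size is expected from compound 3 to compound 4, namely a number 0.27 log units higher from compound 3 to compound 4 (within the scatter). Compound 4 is therefore estimated at 1.53, between 1.2 and 1.85.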

Compound 4, partition coefficient: 1.53
For compound 4 middle estimate and measured number coincide at the digits printed; the measured number falls inside the stated range.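

Bromo in place of chloro on an aromatic carbon gave, in this assay, a number 0.27 log units higher from compound 3 to compound 4 (within the scatter), and the same change on the other core gave a number 0.27 log units higher from compound 1 to compound 2 (within the scatter), so in these two pairs the step has the same size on both cores. This agreement does not establish that the change separates the compounds of either pair, as both steps lie within the scatter, and two pairs on two cores make no rule for any further core. Nothing presented here accounts for the size of the step or for its agreement between the cores.

The compounds shown leave open what fluoro, methyl or trifluoromethyl would give at this place on the 4-substituted phenyl ring of either core. They also leave open whether the step would stay the same size on a core in which the carboxylic acid gives way to a methyl ester or a primary amide.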